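This account rests on a few compounds, and the source may have more. Where it says the series, first, only, none or still open, it means among the compounds named here.

Measured so far:
Compound 1 `CCOC(=O)/C=C1/[C@H](C)O[C@@H](O[Si](C)(C)C(C)(C)C)C[C@@H]1OC` gives 0.01 ug/mL in a functional assay on the whole organism for inhibition, with Artemia salina as the target; a higher number here means a weaker inhibitor of growth, a lower number a stronger inhibitor of growth.
Compound 2 `CO[C@H]1C[C@H](O[Si](C)(C)C(C)(C)C)O[C@@H](C)/C1=C/C#N` gives 0.0005 ug/mL in this assay.

Compound 2 holds the lowest of the two numbers, with compound 1 the nearest at a gap that lies beyond the scatter. Compound 3 `CO[C@H]1C[C@H](O[Si](C)(C)C(C)(C)C)O[C@@H](C)/C1=C/CN1CCNCC1` differs from compound 2 by (piperazin-1-yl)methyl in place of cyano on a double-bonded chain carbon bound to a double-bonded ring carbon. Going by the values given here, only one measured step touches this position, a number 4.3 two-fold dilutions lower from compound 1 to compound 2 (beyond the scatter), which shows that a change here moves the read-out a great deal; no step covers the group that now enters. Compound 3 is therefore expected to be a weaker inhibitor than compound 2, by a number 4.3 two-fold dilutions higher from compound 2 to compound 3 (beyond the scatter). Compound 3 is estimated at 0.01 ug/mL, within 0.001 ug/mL to 0.2 ug/mL.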

Compound 3, minimum inhibitory concentration: 0.002 ug/mL
Compound 3: the middle estimate sits 2.3 two-fold dilutions above what was measured, and the stated range covers the measured number.
By their numbers in this assay, from the lowest: compound 2; then compound 3; then compound 1.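

In this assay, the position accepts a much larger group with only a modest cost, a number 2 two-fold dilutions higher from compound 2 to compound 3 (beyond the scatter), so the nitrile is not needed for a low number. The piperazine-bearing chain also still outperforms the ester, with a number 2.3 two-fold dilutions lower from compound 1 to compound 3 (beyond the scatter), although cyano remains the lowest of the three. No supporting data explain these shifts. The compounds shown leave open whether the piperazine ring matters or a simpler amine, such as dimethylaminomethyl, would do the same, and how a carboxylic acid would behave on this chain carbon.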